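One Amine Swap, Two Cores, One Cytotoxicity Estimate

The compounds below may be only part of what the source reports. "The series", "measured", "known", "first", "only" and "open" are said of these compounds alone.

compound 1 `OCc1cc(N2CCCC2)ccc1-c1nc2c(s1)C(O)CCC2`: 17000 nM
compound 2 `CN(C)c1ccc(-c2nc3c(s2)C(O)CNC3)c(CO)c1`: 70000 nM
compound 3 `OCc1cc(N2CCCC2)ccc1-c1nc2c(s1)C(O)CNC2`: > 100000 nM (a limit)

These three were tested in a functional assay on MCF-10A cells (Homo sapiens) for cytotoxicity, read by sulforhodamine B assay, with a stated time of 2 days; a higher number here means a weaker inhibitor, a lower number a stronger inhibitor. Compound 1 gives 17000 nM in this assay. Compound 2 gives 70000 nM in this assay. For compound 3 the this assay reports only a limit, > 100000 nM, not a number. Compound 1 therefore stands lowest of the two numbers, and its gap to compound 2 lies beyond the scatter.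

Compound 3 and compound 2 differ in one place: dimethylamino in place of pyrrolidin-1-yl on an aromatic carbon. That change gave an at least 1.4-fold lower number from compound 3 to compound 2 (0.15 log units; that floor lies within the scatter), and the step is known only as a floor because one of the two values is a limit (the limit of > 100000 nM in this assay, at which 1 of the 3 values shown sits).

Compound 4 `CN(C)c1ccc(-c2nc3c(s2)C(O)CCC3)c(CO)c1`, not yet measured, relates to compound 1 as compound 2 relates to compound 3: dimethylamino in place of pyrrolidin-1-yl on an aromatic carbon. The place is the same word for word, so this is the same change. The cores of compound 1 and compound 3 differ, but that difference is not broken down here.

Compound 4 is expected to move from compound 1 by a 1.2-fold lower number from compound 1 to compound 4 (0.08 log units; within the scatter), a small step that rests on an at least 1.4-fold lower number from compound 3 to compound 2 (0.15 log units; that floor lies within the scatter), a floor lying within the scatter. Compound 4 is thus estimated at 14000 nM in this assay, expected to fall between 5000 nM and 40000 nM.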

Compound 4, half-maximal inhibitory concentration: > 100000 nM
Compound 4 was reported as a limit; the forecaster's own chance of this, stated with the estimate: 5%; middle value at least 7.1-fold (0.85 log units) away from the limit.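

In this assay, putting dimethylamino in place of pyrrolidin-1-yl on the core of compound 1 gave an at least 5.8-fold higher number from compound 1 to compound 4 (0.76 log units; beyond the scatter), so on this core the change produced a clearly weaker compound. The same change does not carry over from one core to the other at the same size, and a result from one of these cores would have been a poor guide to the other: the same change on two cores in this assay, an at least 1.4-fold lower number (0.15 log units; that floor lies within the scatter) from compound 3 to compound 2 and an at least 5.8-fold higher number (0.76 log units; beyond the scatter) from compound 1 to compound 4, at least 8.4-fold (0.92 log units) apart, beyond the scatter of two such steps
What this does not show is why the two cores part ways, or how large either step truly is, since each step rests on a value reported only as a limit and so gives a floor rather than a measured size: the limit of > 100000 nM in this assay, at which 2 of the 4 values shown sit.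

The compounds shown leave open whether this split between the cores would also appear with other amines on the same aromatic carbon, such as piperidine, morpholine or azetidine. They also leave open whether it would persist if the hydroxymethyl group gave way to a carboxylic acid or a longer chain.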